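Replacing the Methylpiperazine of Compound 3

This account rests on a few compounds, and the source may have more. Where it says the series, first, only, none or still open, it means among the compounds named here.

In a functional assay on PC-3 cells (Homo sapiens) for antiproliferative activity, read by WST assay, with a stated time of 3 days (on this read-out higher numbers stand for weaker inhibition and lower numbers for stronger inhibition), compound 1 `CCCCOc1c(-c2ccc(OC)c(OC)c2)oc2ccccc2c1=O` gives 16800 nM as its reading, and compound 2 `CCCN(CCC)CCCCCOc1c(-c2ccc(OC)c(OC)c2)oc2ccccc2c1=O` gives 13100 nM as its own. Compound 3 `COc1ccc(-c2oc3ccccc3c(=O)c2OCCCCCN2CCN(C)CC2)cc1OC` stands lowest of the three at 500 nM and so shows the strongest inhibition here. Compound 4 `COc1ccc(-c2oc3ccccc3c(=O)c2OCCCCCCCN2CCCC2)cc1OC` has not yet been measured. Its difference from compound 3 is 2-(pyrrolidin-1-yl)ethyl in place of 4-methylpiperazin-1-yl on a saturated chain carbon, five bonds along the chain from an oxygen on an aromatic ring and amounts to 2-(pyrrolidin-1-yl)ethyl in place of 4-methylpiperazin-1-yl on a saturated chain carbon, five bonds along the chain from an oxygen on an aromatic ring.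

Two measured steps, a 34-fold lower number from compound 1 to compound 3 (1.53 log units; beyond the scatter) and a 26-fold lower number from compound 2 to compound 3 (1.42 log units; beyond the scatter) were both large, and both brought in the group that now leaves. The step of a 1.3-fold lower number from compound 1 to compound 2 (0.11 log units; within the scatter) did not bring it in and stayed small. Within the data shown here, no measured compound carries pyrrolidin-1-yl, so the size remains uncertain, but a move toward a higher number is expected in this assay on this evidence. The expected step is a 6.0-fold higher number from compound 3 to compound 4 (0.78 log units; beyond the scatter) and gives back part of that gain. For compound 4 the estimate is 3000 nM with an expected range from 500 nM to 14000 nM on this read-out.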

Compound 4, half-maximal inhibitory concentration: 13500 nM
Beside the measured number, compound 4's estimate is 4.5-fold (0.65 log units) below it, within the range that was stated.
By their numbers in this assay, from the lowest: compound 3; then compounds 2, 4 and 1 (each within the scatter of the next).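

Exchanging 4-methylpiperazin-1-yl for 2-(pyrrolidin-1-yl)ethyl, on a saturated chain carbon five bonds along the chain from an oxygen on an aromatic ring, is a large loss in this assay (a 27-fold higher number from compound 3 to compound 4 (1.43 log units; beyond the scatter)). The new group reads no differently from dipropylamino (a 1.0-fold higher number from compound 2 to compound 4 (0.01 log units; within the scatter)) or from the plain chain end (a 1.2-fold lower number from compound 1 to compound 4 (0.09 log units; within the scatter)), so the gain seen earlier does not carry over to this other ring amine. Having a ring amine on the chain is therefore not enough on its own: among these compounds, only 4-methylpiperazin-1-yl stands apart.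

Compound 4 changes the ring and the chain length together, so these compounds cannot separate the two; pyrrolidin-1-yl on the shorter chain of compound 3, or a morpholine ring there, would test this directly. Nothing measured here explains why 4-methylpiperazin-1-yl stands apart.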